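Adding a methoxy group to compound 3

The source may hold more compounds than are shown below. What is called first, only, known or untested is meant among the compounds shown, and "the series" means these compounds.

Three compounds share one core and differ in a single group: compound 1 `Brc1ccc2[nH]c(-c3cn(-c4ccccc4)nc3-c3ccccc3)nc2c1` carries bromo, compound 2 `COc1ccc2[nH]c(-c3cn(-c4ccccc4)nc3-c3ccccc3)nc2c1` carries methoxy and compound 3 `FC(F)(F)c1ccc2[nH]c(-c3cn(-c4ccccc4)nc3-c3ccccc3)nc2c1` carries trifluoromethyl. In a functional assay on MCF7 cells (Homo sapiens) for antiproliferative activity, read by MTT assay, with a stated time of 48 h (on this read-out higher numbers stand for weaker inhibition and lower numbers for stronger inhibition), compound 1 gives 830 nM, compound 2 gives 1590 nM and compound 3 gives 2660 nM. The spread is small. There is a 3.2-fold higher number from compound 1 to compound 3 (0.51 log units; beyond the scatter), while a 1.9-fold higher number from compound 1 to compound 2 (0.28 log units; within the scatter) and a 1.7-fold higher number from compound 2 to compound 3 (0.22 log units; within the scatter) are smaller. Compound 3 therefore sits with compound 2 within the scatter, and its number stands above that of compound 1.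

Compound 4 `COc1ccc(-c2nn(-c3ccccc3)cc2-c2nc3cc(C(F)(F)F)ccc3[nH]2)cc1` keeps the trifluoromethyl group but turns a phenyl into 4-methoxyphenyl, with methoxy in place of hydrogen on an aromatic carbon. Going by the values given here, no measured step touches that ring, so the evidence is only indirect. The three known steps all swap one group for another on the core, and the largest of them, a 3.2-fold higher number from compound 1 to compound 3 (0.51 log units; beyond the scatter), is only modest. Nothing here indicates a clear direction for the new change, so a large shift in this assay seems unlikely. The expected step is a 1.3-fold lower number from compound 3 to compound 4 (0.12 log units; within the scatter), which stays within the scatter. Compound 4 is estimated at 2000 nM, with an expected range from 700 nM to 5500 nM.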

Compound 4, half-maximal inhibitory concentration: 5730 nM
Compound 4: middle estimate off by 2.9-fold (0.46 log units), on the low side; measured number above the stated range.
By their numbers in this assay, from the lowest: compounds 1, 2 and 3 (each within the scatter of the next, the first and the last beyond it); then compound 4.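

In this assay, the change from phenyl to 4-methoxyphenyl gives a 2.2-fold higher number from compound 3 to compound 4 (0.33 log units; beyond the scatter), so this ring is not a silent spot: the first change measured here moves the number beyond the scatter, towards weaker inhibition. Going by these compounds alone, the changes among compounds 1, 2 and 3 all lay elsewhere on the shared core and said nothing about this ring; the new step is modest, as is a 3.2-fold higher number from compound 1 to compound 3 (0.51 log units; beyond the scatter), the only one of those earlier steps beyond the scatter. Nothing measured here explains why adding methoxy at this place goes with weaker inhibition.

Going by these compounds, it remains open whether this weakening belongs to methoxy itself or would follow any group at this place, and a fluorine atom, a methyl or a hydroxyl on the same ring would help to separate those two readings. On these data alone, it also remains open whether 4-methoxyphenyl would give a step of similar size on the core of compound 1, with bromo in place of trifluoromethyl.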